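From methoxy to hydroxy on compound 3

The compounds below may be only part of what the source reports. "The series", "measured", "known", "first", "only" and "open" are said of these compounds alone.

Among the compounds with values here, three related compounds have numbers so far in a functional assay on cells (CNS carcinoma cell, Homo sapiens) for cytotoxicity, read by sulforhodamine B assay, with a stated time of 48 h (a lower number here means a stronger inhibitor of growth, a higher number a weaker inhibitor of growth), for this series. Compound 1 (`COc1ccc2c(c1)/C(=C/c1c(-c3ccncc3)nc3sccn13)C(=O)N2C`) reads 63100 nM there, and compound 2 (`COc1cc2c(cc1C)NC(=O)/C2=C/c1c(OC)nc2sc(C)cn12`) reads 20400 nM there. Compound 3 (`COc1ccc2c(c1)/C(=C\c1c(OC)nc3sc(C)cn13)C(=O)N2`) reads 33600 nM there, the middle one of the three numbers, yet it lies within the usual scatter of both others, so it cannot be firmly ranked against either.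

Compound 4 (`COc1nc2sc(C)cn2c1/C=C1/C(=O)Nc2ccc(O)cc21`) has not been measured yet. It differs from compound 3 by one small change (hydrogen in place of methyl on an oxygen on an aromatic ring), which is hydrogen in place of methyl on an oxygen on an aromatic ring, or methoxy to hydroxy.

Within the data shown here, only one measured step comes close (a 1.6-fold higher number from compound 2 to compound 3 (0.22 log units; within the scatter)). It also puts hydrogen in place of methyl, though on an aromatic carbon and not on an oxygen. Among the measured compounds shown here, that step stayed within the scatter, but its different place makes it a weak guide, and no measured pair shows methoxy going to hydroxy. No shift beyond the scatter is therefore expected in either direction, and the estimated move (a 1.1-fold lower number from compound 3 to compound 4 (0.05 log units; within the scatter)) is small. For compound 4 the estimated value is 30000 nM with an expected range from 12000 nM to 75000 nM in this assay when it is measured.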

Compound 4, concentration for total growth inhibition: 64000 nM
Compound 4: middle estimate off by 2.1-fold (0.33 log units), on the low side; measured number inside the range.
By their numbers in this assay, from the lowest: compounds 2, 3, 1 and 4 (each within the scatter of the next, the first and the last beyond it).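

In this assay, replacing the methyl on this oxygen with hydrogen, the change from methoxy to hydroxy, gives a 1.9-fold higher number from compound 3 to compound 4 (0.28 log units; within the scatter), so the two compounds cannot be told apart in this assay. Within the data shown here, this is the first direct reading of a change on this oxygen: the earlier step, a 1.6-fold higher number from compound 2 to compound 3 (0.22 log units; within the scatter), also put hydrogen in place of methyl, but on an aromatic carbon, and now neither swap leaves the scatter at its own place. Nothing available explains why the hydroxy compound reads as it does, and no supporting measurement bears on this result.

The compounds shown leave open whether a different group on this oxygen, such as an ethyl or a longer chain ending in an amine, would move the number beyond the scatter in either direction. They also leave open whether methoxy to hydroxy would read the same at the second methoxy, which compound 4 still carries, and whether a single pair on this core holds for other compounds in the series.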